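Replacing the chlorophenyl on the cyclopropane of compound 3

The compounds below may be only part of what the source reports. "The series", "measured", "known", "first", "only" and "open" are said of these compounds alone.

Of the compounds shown here, three sharing one core have been measured in a functional assay for agonist activity at G protein-coupled receptor 88 (Homo sapiens), read by HTRF and cAMP accumulation; on this read-out lower numbers stand for an effect already at smaller amounts and higher numbers for an effect only at larger amounts of compound. Compound 1 `CC(C)C[C@@H](N)CN(C(=O)[C@@H]1C[C@H]1c1ccccc1)c1ccc(-c2ccccc2)cc1` gives 1.8 nM, compound 2 `CC(C)(C)[C@H](N)CN(C(=O)[C@@H]1C[C@H]1c1ccccc1)c1ccc(-c2ccccc2)cc1` gives 11 nM, and compound 3 `CC[C@H](C)[C@H](N)CN(C(=O)[C@@H]1C[C@H]1c1ccc(Cl)cc1)c1ccc(-c2ccccc2)cc1` gives 4300 nM, the highest number of the three and far from both others. Within the data shown here, the only measured single-point step, a 6.1-fold higher number from compound 1 to compound 2 (0.79 log units; beyond the scatter), concerns the amine-bearing side chain, not the ring on the cyclopropane. Compound 4 `CC[C@H](C)[C@H](N)CN(C(=O)[C@@H]1C[C@H]1c1ncccn1)c1ccc(-c2ccccc2)cc1` differs from compound 3 by pyrimidin-2-yl in place of 4-chlorophenyl on a saturated ring carbon. Among the measured compounds shown here, no measured pair speaks to this exchange, so the data give no direction for it. The step is therefore expected to be about a 1.4-fold higher number from compound 3 to compound 4 (0.14 log units; within the scatter), with wide uncertainty. Compound 4 is estimated at 6000 nM, within 1500 nM to 25000 nM.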

Compound 4, half-maximal effective concentration: 130 nM
Compound 4: the middle estimate sits 46-fold (1.66 log units) above what was measured; the measured number lies below the stated range.
By their numbers in this assay, from the lowest: compound 1; then compound 2; then compound 4; then compound 3.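

The ring on the cyclopropane matters strongly: with the rest of compound 3 unchanged, pyrimidin-2-yl in place of 4-chlorophenyl gives a 33-fold lower number from compound 3 to compound 4 (1.52 log units; beyond the scatter) in this assay. A change at this saturated ring carbon can therefore move the number a long way, and the direction favours the ring with 2 hetero atoms over the chlorine-bearing carbon ring here. Nothing available explains the step.

Still open, going by these compounds, is whether pyridin-2-yl would give a similar step, which would help separate the part played by the ring nitrogens from the loss of chlorine. Also open, on these data alone, is whether pyrimidin-2-yl acts alike alongside the 1-amino-3-methylbutyl side chain.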